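Fluoro for methyl in the benzophenone acid series

The source may report more compounds than this note shows. Statements on the series, on what has been measured and on what is new or still open speak of the compounds shown alone.

Measured compounds:
compound 1, `O=C(O)c1ccc(C(=O)c2ccc(OC(c3ccccc3)c3ccccc3)cc2)cc1`, 71%
compound 2, `Cc1cc(CC(=O)O)ccc1C(=O)c1ccc(Oc2ccccc2)cc1`, 78%
compound 3, `O=C(O)c1ccc(C(=O)c2ccc(OCc3cc(C(F)(F)F)ccc3C(F)(F)F)cc2)cc1`, 29%

All three were tested in an assay for displacement of a labelled ligand from 3-oxo-5-alpha-steroid 4-dehydrogenase 2 (Rattus norvegicus), at pH 5.5, tested at 10 uM; on this read-out lower numbers stand for less inhibition and higher numbers for more inhibition at the one concentration tested (going by the name of the read-out). Compound 2 gives the highest of the three numbers, but the gap to compound 1 lies within the scatter, so no order between compound 2 and compound 1 can be read from these values. Compound 3 sits well apart, its number lying beyond the scatter from that of compound 2.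

Compound 4, `O=C(O)Cc1ccc(C(=O)c2ccc(Oc3ccccc3)cc2)c(F)c1`, has not yet been measured in this assay. It differs from compound 2 in a single place: fluoro in place of methyl on an aromatic carbon. The carboxymethyl group, the carbonyl and the phenoxy group are kept unchanged.

For the measured compounds named here, no measured pair isolates this exchange, so the expectation rests on compound 2 alone, with its value 78%. The change is confined to one heavy atom on an aromatic carbon, so a step within the scatter is expected, in either direction, with a slight lean downward. The expected step is a number 8 percentage points lower from compound 2 to compound 4 (within the scatter). Compound 4 is accordingly expected to give about 70% in this assay, within 50% to 88%.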

Compound 4, a percentage reported as inhibition, at one concentration (the size of the read-out at that concentration, not a potency): 73%
Estimate against measurement, compound 4: 3 percentage points below; low and high end bracket the measured number.
By their numbers in this assay, from the lowest: compound 3; then compounds 1, 4 and 2 (each within the scatter of the next).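

In this assay, fluoro in place of methyl on this aromatic carbon, ortho to a large group and meta to a carboxymethyl group, gives a number 5 percentage points lower from compound 2 to compound 4 (within the scatter). For the compounds shown here, this is the only step that isolates a single exchange, and it shows that at this position the read-out at the one concentration tested does not separate fluoro from methyl. No measurement shown bears on why the two groups read alike.

On these data alone, whether a larger or different group on this aromatic carbon, such as a methoxy group or an amine, would also stay within the scatter remains open. Also open, as far as these compounds go, is whether the exchange would read the same with a longer chain in place of the carboxymethyl group.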